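Chain Extension on the Core: Butyl to Isopentyl

The source may report more compounds than this note shows. Statements on the series, on what has been measured and on what is new or still open speak of the compounds shown alone.

Compound 1 `CCCCc1nc(=O)c(S(=O)(=O)c2ccc(-c3ccc(F)nc3)cc2)c(O)n1-c1c(OC)cccc1OC`: 516 nm/s
Compound 2 `CCCCc1nc(=O)c(S(=O)(=O)c2ccc(-n3ccccc3=O)cc2)c(O)n1-c1c(OC)cccc1OC`: 12 nm/s
Compound 3 `CCCCc1nc(=O)c(S(=O)(=O)c2ccc(-n3cc(Cl)ccc3=O)cc2)c(O)n1-c1c(OC)cccc1OC`: 83 nm/s

In an ADME assay for permeability, using PAMPA, at pH 5.5 (on this read-out higher numbers stand for higher permeability and lower numbers for lower permeability), compound 1 gives the highest of the three numbers; the nearest is a 6.2-fold lower number from compound 1 to compound 3 (0.79 log units; beyond the scatter) and the furthest is a 43-fold lower number from compound 1 to compound 2 (1.63 log units; beyond the scatter). Compound 4 `COc1cccc(OC)c1-n1c(CCC(C)C)nc(=O)c(S(=O)(=O)c2ccc(-c3ccc(F)nc3)cc2)c1O` differs from compound 1 by methyl in place of hydrogen on a saturated chain carbon bound to two saturated chain carbons, that is, butyl to isopentyl on the shared core. For the measured compounds named here, every measured step, including a 6.9-fold higher number from compound 2 to compound 3 (0.84 log units; beyond the scatter), concerns the ring at the far end of the sulfonyl arm, not this chain, so no measured step bears on the change directly. A step within the usual scatter is therefore expected, a 1.2-fold higher number from compound 1 to compound 4 (0.07 log units; within the scatter). Compound 4 is estimated at 600 nm/s in this assay, with a range from 280 nm/s to 1300 nm/s.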

Compound 4, apparent permeability: 246 nm/s
For compound 4 the middle estimate is 2.4-fold (0.39 log units) above the measured one; the whole stated range lies above it.
By their numbers in this assay, from the lowest: compound 2; then compound 3; then compound 4; then compound 1.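

Every earlier step concerned the ring at the far end of the sulfonyl arm, whereas here the chain on the shared core changes, and in this assay butyl to isopentyl gives a 2.1-fold lower number from compound 1 to compound 4 (0.32 log units; beyond the scatter) for one added methyl. This chain position therefore affects the read-out, even though the change is small and the step modest. No measurement at hand gives a cause for this drop. Still open, from the compounds shown here alone, is how a longer chain, such as hexyl, or a chain ending in an amine would read here.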